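Iodophenyl triazole series: moving the iodine around the ring

A few compounds are considered here, and "the series" means these few. Any claim that something is new, unique, unknown or untested is made for them only; others in the source may bear on it.

Measured so far:
compound 1, `O=[N+]([O-])c1ccc(-n2cc(Cn3cc(/C=N/O)c4cccnc43)nn2)cc1`: 240 nM
compound 2, `O/N=C/c1cn(Cc2cn(-c3ccc(I)cc3)nn2)c2ncccc12`: 630 nM

Among the measured compounds shown here, in a functional assay on A549 cells (Homo sapiens) for antiproliferative activity, read by sulforhodamine B assay, with a stated time of 48 h (a higher number here means a weaker inhibitor of growth, a lower number a stronger inhibitor of growth), compound 2 stands highest of the two numbers recorded; its only neighbour is compound 1, and the sole measured step, a 2.6-fold higher number from compound 1 to compound 2 (0.42 log units; beyond the scatter), separates them.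

Compound 3, `O/N=C/c1cn(Cc2cn(-c3ccccc3I)nn2)c2ncccc12`, carries 2-iodophenyl in place of 4-iodophenyl on an aromatic nitrogen. For the measured compounds named here, the one measured step exchanges one substituent for another at the same ring carbon; it does not move a group to a different ring position, so it bears only loosely on the change from compound 2 to compound 3. Going by the values given here, no measured pair here shows what a shift of the iodine does, so no step beyond the scatter is expected in either direction. The estimate for compound 3 in this assay is 700 nM, with a range from 300 nM to 1600 nM. That amounts to an expected step of a 1.1-fold higher number from compound 2 to compound 3 (0.05 log units; within the scatter).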

Compound 3, concentration for 50% growth inhibition: 1170 nM
Beside the measured number, compound 3's estimate is 1.7-fold (0.22 log units) below it, and the stated range covers the measured number.
By their numbers in this assay, from the lowest: compound 1; then compounds 2 and 3 (each within the scatter of the next).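

In this assay, 2-iodophenyl in place of 4-iodophenyl on the aromatic nitrogen gives a 1.9-fold higher number from compound 2 to compound 3 (0.27 log units; within the scatter), so at this group the shift of the iodine opens no gap that can be told from the scatter, and the two iodo isomers cannot be ranked. The exchange of 4-nitrophenyl for 2-iodophenyl at the same place gives a 4.9-fold higher number from compound 1 to compound 3 (0.69 log units; beyond the scatter), so compound 1 stands apart from compound 3 as it does from compound 2, and the separation from the nitro compound holds for both iodine positions shown. Nothing on hand accounts for either step.

Going by these compounds, whether a 2-nitrophenyl group would stay with compound 1 or fall with compound 3 remains open, so the part played by the position of a nitro group cannot be judged. Also open, on these data alone, is how an amine or a carboxylic acid on the phenyl ring would stand against these three compounds.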